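A few compounds are considered here, and "the series" means these few. Any claim that something is new, unique, unknown or untested is made for them only; others in the source may bear on it.

Measured in a functional assay (trachea) with Cavia porcellus as the target; a lower number here means a stronger inhibitor, a higher number a weaker inhibitor:
- Compound 1 `CCOC(=O)CCCn1nc(-c2cccnc2)c2ccccc2c1=O`: 10000 nM
- Compound 2 `O=c1c2ccccc2c(-c2cccnc2)nn1CCSc1ncccn1`: 11000 nM

Compound 2 cannot be told apart from compound 1 on these numbers, because the two values lie within the usual scatter of repeated measurements. Both sit at the same level, and neither can be called the better inhibitor.

The next structure is compound 3 `O=c1c2ccccc2c(-c2cccnc2)nn1CCCCSc1ncccn1`, which keeps the shared core and differs only at the end of the side chain: 2-((pyrimidin-2-yl)sulfanyl)ethyl in place of (pyrimidin-2-yl)sulfanyl on a saturated chain carbon, two bonds along the chain from an aromatic nitrogen. Here 2-((pyrimidin-2-yl)sulfanyl)ethyl stands in place of (pyrimidin-2-yl)sulfanyl, on a saturated chain carbon, two bonds along the chain from an aromatic nitrogen.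

Among the measured compounds shown here, only one measured step bears on this change: a 1.1-fold higher number from compound 1 to compound 2 (0.04 log units; within the scatter). That step lies within the scatter, although it exchanged one chain end for a quite different one. For the measured compounds named here, no measured pair tests a change of this kind directly, so the evidence is thin. On that single step, no shift beyond the scatter is expected in this assay, in either direction.

The expected step is a 1.1-fold lower number from compound 2 to compound 3 (0.04 log units; within the scatter). For compound 3 the estimated value is 10000 nM, with an expected range of 4000 nM to 25000 nM.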

Compound 3, half-maximal inhibitory concentration: 6170 nM
For compound 3 the middle estimate is 1.6-fold (0.21 log units) above the measured one; low and high end bracket the measured number.
By their numbers in this assay, from the lowest: compounds 3, 1 and 2 (each within the scatter of the next).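

In this assay, putting 2-((pyrimidin-2-yl)sulfanyl)ethyl in place of (pyrimidin-2-yl)sulfanyl on a saturated chain carbon, two bonds along the chain from an aromatic nitrogen, gives a 1.8-fold lower number from compound 2 to compound 3 (0.25 log units; within the scatter), so a longer chain carrying the same pyrimidine end does not separate from the shorter one on these numbers. Comparing the chain ends gives the same reading, with ((pyrimidin-2-yl)sulfanyl)methyl in place of ethoxycarbonyl giving a 1.6-fold lower number from compound 1 to compound 3 (0.21 log units; within the scatter), so all three compounds form a single group in this assay, and none can be called the better inhibitor. No measurement is available that would explain why these side chains read alike.

The compounds shown do not reveal whether anything at this position can move the number beyond the scatter, since every step so far stays inside it. A chain ending in an amine or a carboxylic acid, or a chain longer than 2-((pyrimidin-2-yl)sulfanyl)ethyl, would be a natural further test of how much this side chain matters in this assay, and the answer cannot be drawn from these compounds.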